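Working notes: the step from compound 3 to compound 4

The source may hold more compounds than are shown below. What is called first, only, known or untested is meant among the compounds shown, and "the series" means these compounds.

In a functional assay on HL-60 cells (Homo sapiens) for inhibition, read by MTT assay, with a stated time of 72 h (a lower number here means a stronger inhibitor, a higher number a weaker inhibitor), compound 1 (`Cc1ccc(C)c(N2CCN(C(=O)c3oc(C)nc3-c3ccccc3)CC2)c1`) gives 31.3 nM and compound 3 (`COc1cccc(N2CCN(C(=O)c3oc(C)nc3-c3ccccc3)CC2)c1`) gives 34.8 nM in the same read-out. Compound 2 (`CC(=O)c1ccc(N2CCN(C(=O)c3oc(C)nc3-c3ccccc3)CC2)cc1`) is reported as "not active" (no number reported) with no number. Compound 3 stands level with compound 1, the measured step being a 1.1-fold higher number from compound 1 to compound 3 (0.05 log units; within the scatter) at the place now in question. Compound 4 (`Cc1nc(-c2ccccc2)c(C(=O)N2CCN(c3ccccc3C(F)(F)F)CC2)o1`) has 2-(trifluoromethyl)phenyl in place of 3-methoxyphenyl on an amine nitrogen in a ring. Within the data shown here, that step is the only numerical guide, while compound 2, changed at the same place, is reported as "not active" (no number reported) and so widens the range. No step beyond the scatter is expected, the estimated step being a 1.0-fold higher number from compound 3 to compound 4 (0.00 log units; within the scatter) in this series. The estimate for compound 4 is 35 nM with an expected range from 10 nM to 150 nM in this read-out.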

Compound 4, half-maximal inhibitory concentration: 120 nM
For compound 4 the middle estimate is 3.4-fold (0.54 log units) below the measured one, and the stated range covers the measured number.
By their numbers in this assay, from the lowest: compounds 1 and 3 (each within the scatter of the next); then compound 4.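

In this assay the group on the amine nitrogen in a ring now shifts the number beyond the scatter, with a 3.4-fold higher number from compound 3 to compound 4 (0.54 log units; beyond the scatter) and with a 3.8-fold higher number from compound 1 to compound 4 (0.58 log units; beyond the scatter) for the change to 2-(trifluoromethyl)phenyl. The earlier numerical step at this place stayed within the scatter, so compound 4 gives the first measured loss of inhibition at this position while retaining a number. No available measurement accounts for this loss.

The trifluoromethyl group itself and its place on the phenyl ring cannot be separated on these compounds. On these data alone, how a carboxylic acid or an amine on that phenyl ring would read remains open.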